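The compounds below may be only part of what the source reports. "The series", "measured", "known", "first", "only" and "open" are said of these compounds alone.

Series around the core of compound 1 `Cc1c(F)c(N)c2c(=O)cc(-c3ccc(N)c(F)c3)oc2c1F`. In a functional assay on MCF7 cells (Homo sapiens) for cytotoxicity, read by neutral red uptake, with a stated time of 3 days (on this read-out higher numbers stand for weaker inhibition and lower numbers for stronger inhibition), compound 1 gives 13 nM. Compound 2 `CCCCc1c(F)c(N)c2c(=O)cc(-c3ccc(N)c(F)c3)oc2c1F` carries propyl in place of hydrogen on a saturated chain carbon bound to an aromatic carbon; in this assay compound 2 gives 8800 nM, and a 680-fold higher number from compound 1 to compound 2 (2.83 log units; beyond the scatter). Compound 3 `CCCOCc1c(F)c(N)c2c(=O)cc(-c3ccc(N)c(F)c3)oc2c1F` differs from compound 1 by propoxy in place of hydrogen on a saturated chain carbon bound to an aromatic carbon; in this assay compound 3 gives 1200 nM, so a 92-fold higher number from compound 1 to compound 3 (1.97 log units; beyond the scatter) and a 7.3-fold lower number from compound 2 to compound 3 (0.87 log units; beyond the scatter). Compound 4 `CCCCCCOCc1c(F)c(N)c2c(=O)cc(-c3ccc(N)c(F)c3)oc2c1F` is not yet measured and differs from compound 3 by propyl in place of hydrogen on a saturated chain carbon, three bonds along the chain from an oxygen on a saturated carbon. This is the same kind of change as between compound 1 and compound 2, not the same: there the place was on a saturated chain carbon bound to an aromatic carbon, here three bonds along the chain from an oxygen on a saturated carbon. A weaker step is expected for compound 4 because a 680-fold higher number from compound 1 to compound 2 (2.83 log units; beyond the scatter) occurred with the change close to the core. Compound 4 is thus expected at a 5.0-fold higher number from compound 3 to compound 4 (0.70 log units; beyond the scatter) in this assay. The estimate for compound 4 is 6000 nM, between 1500 nM and 25000 nM.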

Compound 4, half-maximal inhibitory concentration: 7100 nM
Compound 4: middle estimate off by 1.2-fold (0.07 log units), on the low side; the measured number falls inside the stated range.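

In this assay the propyl change gives a 5.9-fold higher number from compound 3 to compound 4 (0.77 log units; beyond the scatter), and its size does not carry over from the earlier case on the chain carbon bound to an aromatic carbon: the same change on two cores in this assay, a 680-fold higher number (2.83 log units; beyond the scatter) from compound 1 to compound 2 and a 5.9-fold higher number (0.77 log units; beyond the scatter) from compound 3 to compound 4, 110-fold (2.06 log units) apart, beyond the scatter of two such steps. Hexyloxy leaves a 550-fold higher number from compound 1 to compound 4 (2.74 log units; beyond the scatter), while hexyloxy in place of propyl gives a 1.2-fold lower number from compound 2 to compound 4 (0.09 log units; within the scatter), so no order can be read between those two. The two pairs show that the size of this step is not transferable here, but not whether core or place accounts for the gap, as both differ together.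

Open, going by these compounds, is whether a longer chain, or a chain ending in an amine or a carboxylic acid, would shift the number further.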